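Chlorine position on the benzyl arm of compound 3

A few compounds are considered here, and "the series" means these few. Any claim that something is new, unique, unknown or untested is made for them only; others in the source may bear on it.

Compound 3 `O=C(O)c1ccccc1-c1ccc(CCc2ncc(Cc3ccc(Cl)cc3)[nH]2)cc1` gives 2290 nM in an in vitro functional assay on cells for agonist activity at Bombesin receptor subtype-3 (Homo sapiens), read by luminescence and calcium flux (on this read-out lower numbers stand for an effect already at smaller amounts and higher numbers for an effect only at larger amounts of compound), the second highest of the three numbers recorded. Among the compounds with values here, compound 2 `CCCCc1cnc(C(Cc2ccc(-c3ccccc3C(=O)O)cc2)C(C)C)[nH]1` at 4620 nM sits within the scatter of it, while compound 1 `O=C(O)c1ccccc1-c1ccc(CCc2ncc(CC3CCCCC3)[nH]2)cc1` at 41 nM is far lower; the only single-site step measured, a 56-fold higher number from compound 1 to compound 3 (1.75 log units; beyond the scatter), came from 4-chlorophenyl in place of cyclohexyl on a saturated chain carbon bound to an aromatic carbon. Compound 4 `O=C(O)c1ccccc1-c1ccc(CCc2ncc(Cc3cccc(Cl)c3)[nH]2)cc1` differs from compound 3 by 3-chlorophenyl in place of 4-chlorophenyl on a saturated chain carbon bound to an aromatic carbon. Within the data shown here, no measured step moves the chlorine around the ring, so nothing here bears directly on this change; the large step from compound 1 concerns a different exchange. A step no larger than the scatter is therefore expected, in either direction. Compound 4 is estimated at 2000 nM, within 700 nM to 6000 nM, meaning an expected 1.1-fold lower number from compound 3 to compound 4 (0.06 log units; within the scatter).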

Compound 4, half-maximal effective concentration: 825 nM
Estimate against measurement, compound 4: 2.4-fold (0.38 log units) above; the measured number falls inside the stated range.
By their numbers in this assay, from the lowest: compound 1; then compound 4; then compounds 3 and 2 (each within the scatter of the next).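

Moving the chlorine registers in this assay: 3-chlorophenyl in place of 4-chlorophenyl gives a 2.8-fold lower number from compound 3 to compound 4 (0.44 log units; beyond the scatter) and so shows that, on this arm, the ring position of the chlorine matters modestly. The change recovers only a small part of what cyclohexyl offers, with a 20-fold higher number from compound 1 to compound 4 (1.30 log units; beyond the scatter) still separating the two arms. No evidence explains either step.

Still open, from the compounds shown here alone, is how an unsubstituted benzyl or a methoxybenzyl would compare with the 3-chlorobenzyl of compound 4. Going by these compounds, it is also open whether a chlorine on the cyclohexyl of compound 1 would be tolerated.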